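The source may hold more compounds than are shown below. What is called first, only, known or untested is meant among the compounds shown, and "the series" means these compounds.

Three compounds have been measured in a functional assay on MCF7 cells (Homo sapiens) for cytotoxicity, read by MTT assay, with a stated time of 72 h; a higher number here means a weaker inhibitor, a lower number a stronger inhibitor:

Compound 1, `COc1cc(/C=C2\CCC/C(=C\c3cccc(OC)c3OC)C2=O)ccc1O`, gives 11600 nM.
Compound 2, `COc1cccc(/C=C2\CCC/C(=C\c3ccc(O)c(O)c3)C2=O)c1OC`, gives 4700 nM.
Compound 3, `COc1cc(/C=C2\CCC/C(=C\c3ccc(OC)c(OC)c3)C2=O)ccc1O`, gives 7900 nM.

Compound 2 differs from compound 1 in one place only: hydrogen in place of methyl on an oxygen on an aromatic ring. That single change produced a 2.5-fold lower number from compound 1 to compound 2 (0.39 log units; beyond the scatter), a modest but real gain in potency.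

Compound 3 is built from the same atoms as compound 1, joined in a different way; the difference between the two cores is not broken down here. What the two values show is that compound 3 and compound 1 sit close to one another in this assay, and compound 3 is also within the usual spread of compound 2, so no order among these three can be read from the numbers alone.

Compound 4, `COc1ccc(/C=C2\CCC/C(=C\c3ccc(O)c(O)c3)C2=O)cc1OC`, has not yet been measured. It stands to compound 3 exactly as compound 2 stands to compound 1: hydrogen in place of methyl on an oxygen on an aromatic ring. The place of the change is described in the same words for both pairs, so this is the same change made on a different core.

Going by the values given here, with only one earlier example of this change, the expectation rests on a single step. Because that change gave a 2.5-fold lower number from compound 1 to compound 2 (0.39 log units; beyond the scatter), the expected step here is a 2.5-fold lower number from compound 3 to compound 4 (0.39 log units; beyond the scatter). Compound 4 is therefore estimated at about 3200 nM, most likely between 1500 nM and 6500 nM.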

Compound 4, half-maximal inhibitory concentration: 14400 nM
For compound 4 the middle estimate is 4.5-fold (0.65 log units) below the measured one, outside the stated range (above it).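

In this assay, replacing the methoxy with a hydroxy, which turns the 4-hydroxy-3-methoxyphenyl group into a 3,4-dihydroxyphenyl group, gave a 1.8-fold higher number from compound 3 to compound 4 (0.26 log units; within the scatter), so the gain seen on the core of compound 1 did not appear on the core of compound 3. Set side by side, the two results for this one change do not agree: the same change on two cores in this assay, a 2.5-fold lower number (0.39 log units; beyond the scatter) from compound 1 to compound 2 and a 1.8-fold higher number (0.26 log units; within the scatter) from compound 3 to compound 4, 4.5-fold (0.65 log units) apart, beyond the scatter of two such steps This shows that, in this series, the effect of the change cannot simply be carried from one core to another, since the surrounding structure appears to matter; it does not show why the two cores differ, and two pairs cannot tell which result is more typical of the series.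

Every aromatic ring shown carries only methoxy or hydroxy groups, so it remains open how an ethoxy group, an amine or a fluorine in the place of the changed group would behave on either core. Going by these compounds, it also remains open whether the same change, made at another methoxy group on these cores, would follow the first step, the second, or neither.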